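Swapping the Aryl Group on the Ring Nitrogen

The compounds below may be only part of what the source reports. "The series", "measured", "known", "first", "only" and "open" are said of these compounds alone.

Measured so far:
compound 1, `CCOC(=O)C1=C(C)N(c2ccc(Cl)cc2)C=CC1c1ccccc1`, gives -31.1% in a functional assay, tested at 200 ug/mL; a lower number here means a stronger effect, a higher number a weaker effect of the compound at the concentration tested
compound 2, `COC(=O)C1=C(C)N(c2ccc(OC)cc2)C=C(C)C1c1ccccc1`, gives -22.6% in this assay

Of the compounds shown here, two share a core and have been measured in this assay. Compound 2 stands alongside compound 1: its number and that of compound 1 lie within the usual scatter of each other, so the two cannot be told apart on these data. Within the data shown here, compound 1 and compound 2 differ in more than one place, so no single step between them can be read off.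

Compound 3, `COC(=O)C1=C(C)N(c2cccc(Cl)c2)C=C(C)C1c1ccccc1`, has not been measured yet. It differs from compound 2 in one place: 3-chlorophenyl in place of 4-methoxyphenyl on an amine nitrogen in a ring. Among the measured compounds shown here, the two measured compounds give no step that isolates a change on the amine nitrogen, so there is nothing to lean on for direction. The expected step in this assay from compound 2 to compound 3 is a number 3.4 percentage points lower from compound 2 to compound 3 (within the scatter), that is, no change beyond the scatter. For compound 3 the estimated value in this assay is -26%, with a range from -45% to -6%.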

Compound 3, a percentage reported as activity, at one concentration (the size of the read-out at that concentration, not a potency): -23%
Beside the measured number, compound 3's estimate is 3 percentage points below it; the range from low to high includes it.
By their numbers in this assay, from the lowest: compounds 1, 3 and 2 (each within the scatter of the next).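

In this assay, among these compounds, 3-chlorophenyl in place of 4-methoxyphenyl on the amine nitrogen in the ring gives a number 0.4 percentage points lower from compound 2 to compound 3 (within the scatter), the first step that isolates a single change. On this evidence, the read-out at the concentration tested cannot separate these two aryl groups, even though the entering group has a chlorine and 0 hydrogen-bond acceptors while the leaving group has an oxygen and 1 hydrogen-bond acceptor. Nothing available here explains why the two compounds cannot be told apart.

This single step alters both the substituent and its place on the phenyl ring, so the two contributions remain tangled, and 3-methoxyphenyl or 4-chlorophenyl on the core of compound 2 would be needed to pull them apart. As far as these compounds go, it also remains open whether the read-out stays within the scatter when the aryl group gives way to something quite different, such as a benzyl group, a butyl chain or a phenyl ring carrying a carboxylic acid.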